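Adding a chlorine to a weak antiproliferative pyrazole amide

The source may hold more compounds than are shown below. What is called first, only, known or untested is meant among the compounds shown, and "the series" means these compounds.

Measured compounds:
compound 1, `O=C(NOCc1ccccc1F)c1cn(-c2ccccc2)nc1-c1ccccc1`: 16100 nM
compound 2, `O=C(NOCc1ccccc1Cl)c1cn(-c2ccccc2)nc1-c1ccccc1`: 7410 nM

Both compounds were tested in a functional assay on MCF7 cells (Homo sapiens) for antiproliferative activity, read by MTT assay, with a stated time of 48 h, in the presence of a further agent that is not named here; on this read-out lower numbers stand for stronger inhibition of growth and higher numbers for weaker inhibition of growth. Among the two numbers, compound 1 stands highest; its nearest neighbour is compound 2, and the single measured step, a 2.2-fold lower number from compound 1 to compound 2 (0.34 log units; beyond the scatter), consists of chloro in place of fluoro on an aromatic carbon of the benzyl-type ring.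

Compound 3, `O=C(NOCc1ccccc1F)c1cn(-c2ccccc2)nc1-c1ccc(Cl)cc1`, keeps the fluoro of compound 1 and instead alters the other outer ring: chloro in place of hydrogen on an aromatic carbon. The change sits on an aromatic carbon of a six-membered aromatic ring of carbon only, para to a large group; read one bond further out, phenyl becomes 4-chlorophenyl.

Within the data shown here, no measured step touches this ring, so the step from compound 1 to compound 2 bears on it only loosely, as the one example of a chlorine entering the molecule, and it was modest. A small lowering of the number is therefore expected in this assay, near the edge of the scatter, so that the expected step is a 1.6-fold lower number from compound 1 to compound 3 (0.21 log units; within the scatter). Compound 3 is estimated at 10000 nM, within a range from 4000 nM to 30000 nM.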

Compound 3, concentration for 50% growth inhibition: 15100 nM
The estimate for compound 3 lay 1.5-fold (0.18 log units) below the measured number, within the range that was stated.
By their numbers in this assay, from the lowest: compound 2; then compounds 3 and 1 (each within the scatter of the next).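

In this assay, putting chloro in place of hydrogen on this outer ring, para to a large group, gives a 1.1-fold lower number from compound 1 to compound 3 (0.03 log units; within the scatter) and so does not separate the two compounds: at this place, phenyl and 4-chlorophenyl cannot be told apart on this read-out. Among these compounds, the only earlier step, a 2.2-fold lower number from compound 1 to compound 2 (0.34 log units; beyond the scatter), was a swap of fluoro for chloro on the other outer ring, so the two steps together show that the outcome of bringing in a chlorine differs between these two places, at least for this pair of changes. Nothing measured here offers an explanation for that difference between the two steps.

The compounds shown leave open whether this ring accepts any change at this place without a shift in growth inhibition, or whether a different group here, such as an amine, a carboxylic acid or a longer chain, would move the number beyond the scatter. Among the compounds shown here, they also leave open whether 4-chlorophenyl would read the same when combined with the chloro-bearing ring of compound 2, since each change has been seen only on its own.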